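Microsomal half-life across the oxazole acrylamide series

The source may report more compounds than this note shows. Statements on the series, on what has been measured and on what is new or still open speak of the compounds shown alone.

Measured so far:
Compound 1 `C=CC(=O)NCc1coc(-c2c(N)ncnc2Nc2ccc(OCc3ccccn3)c(F)c2)n1`: in an in vitro ADME assay on microsomes from liver (Mus musculus) for metabolic stability, tested at 5 uM (a higher number here means that the compound lasts longer, a lower number that the compound disappears faster), compound 1 gives 0.15 h.
Compound 2 `C=CC(=O)NCc1coc(-c2c(N)ncnc2Nc2ccc(Oc3ccccc3)c(Cl)c2)n1`: in this assay compound 2 gives 0.8 h.

Compound 2 stands highest of the two numbers; compound 1 is the nearest, and the gap between them lies beyond the scatter. Compound 3 `C=CC(=O)NCc1coc(-c2c(N)ncnc2Nc2ccc(Oc3cc(Cl)ccc3Cl)c(Cl)c2)n1` differs from compound 2 by 2,5-dichlorophenyl in place of phenyl on an oxygen on an aromatic ring. Within the data shown here, no measured pair carries this same change, so nothing from the measured compounds sizes it. A step in this assay of modest size is expected, not clearly beyond the scatter, with a slight lean upward. Compound 3 is estimated at 1 h, within a range from 0.4 h to 2.5 h. That estimate means an expected step of a 1.3-fold higher number from compound 2 to compound 3 (0.10 log units; within the scatter).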

Compound 3, half-life: 0.95 h
For compound 3 the middle estimate is 1.1-fold (0.02 log units) above the measured one; low and high end bracket the measured number.
By their numbers in this assay, from the lowest: compound 1; then compounds 2 and 3 (each within the scatter of the next).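

In this assay, among these compounds, 2,5-dichlorophenyl in place of phenyl on an oxygen on an aromatic ring gives a 1.2-fold higher number from compound 2 to compound 3 (0.07 log units; within the scatter) and so provides the first matched reading at this position. The two chlorine atoms that enter leave compound 2 and compound 3 indistinguishable in half-life, so this place tolerates that change on this read-out. No available evidence accounts for this result.

From the compounds shown here alone, whether the same holds for a phenyl carrying an amine or a carboxylic acid remains open. So does whether a longer chain on that oxygen reads the same.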